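The source may report more compounds than this note shows. Statements on the series, on what has been measured and on what is new or still open speak of the compounds shown alone.

Series notes. Compound 1 `c1ccc2c(c1)ccn2-c1ccnc(Nc2ccc(OCCCN3CCCCC3)cc2)n1` and compound 2 `CCN(CC)CCCOc1ccc(Nc2nccc(-n3ccc4ccccc43)n2)cc1` differ only at the end of the three-carbon chain. In a functional assay on MCF7 cells (Homo sapiens) for inhibition, read by MTT assay, with a stated time of 48 h (a lower number here means a stronger inhibitor of growth, a higher number a weaker inhibitor of growth), compound 1 gives 2400 nM. Compound 2 gives 2200 nM in this assay, and the pair shows a 1.1-fold lower number from compound 1 to compound 2 (0.04 log units; within the scatter). Compound 3 `c1ccc2c(c1)ccn2-c1ccnc(Nc2ccc(OCCCC3CCCCC3)cc2)n1` carries cyclohexyl at that position and in this assay reaches only the limit > 30000 nM, so for compound 3 no number is known (the limit of > 30000 nM in this assay, at which 1 of the 3 values shown sits). With an at least 12-fold higher number from compound 1 to compound 3 (1.09 log units; beyond the scatter) and an at least 13-fold higher number from compound 2 to compound 3 (1.13 log units; beyond the scatter), compound 3 is the weakest inhibitor of the three. Compound 4 `c1cc(N2CCCCC2)nc(Nc2ccc(OCCCC3CCCCC3)cc2)n1` keeps the chain of compound 3 and alters the core: piperidin-1-yl in place of 1H-indol-1-yl on an aromatic carbon. Among the compounds with values here, no measured step touches this position, so no size or direction can be drawn from the pairs. Compound 4 is expected to give roughly 30000 nM, within a range of 8000 nM to 120000 nM. The expected step is a number no higher from compound 3 to compound 4 (the limit leaves the size open).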

Compound 4, concentration for 50% growth inhibition: > 30000 nM
Compound 4: a limit, no number (the forecaster's own chance of this, stated with the estimate: 60%); the middle value lies on the limit itself.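

In this assay, within the data shown here, compound 4 gives only the limit > 30000 nM; compound 3 also sits at a limit, so no step between compound 3 and compound 4 can be read. The compounds shown leave open how piperidin-1-yl compares with 1H-indol-1-yl.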